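A few compounds are considered here, and "the series" means these few. Any claim that something is new, unique, unknown or untested is made for them only; others in the source may bear on it.

Measured compounds:
- compound 1, `Fc1ccc(C2=NN(c3nc(-c4ccc(Br)cc4)cs3)C(c3cccs3)C2)cc1`, in a functional assay on MCF7 cells (Homo sapiens) for antiproliferative activity, read by MTT assay, with a stated time of 48 h (on this read-out lower numbers stand for stronger inhibition and higher numbers for weaker inhibition), compound 1 gives 8280 nM
- compound 2, `Fc1ccc(C2=NN(c3nc(-c4ccccc4)cs3)C(c3cccs3)C2)cc1`, in this assay compound 2 gives 2340 nM
- compound 3, `Clc1ccc(C2=NN(c3nc(-c4ccc(Br)cc4)cs3)C(c3cccs3)C2)cc1`, in this assay compound 3 gives 14700 nM

Compound 4, `Clc1ccc(C2=NN(c3nc(-c4ccccc4)cs3)C(c3cccs3)C2)cc1`, has not yet been measured. It is made from compound 3 by a single change, (hydrogen in place of bromo on an aromatic carbon), and the same change has already been measured once, from compound 1 to compound 2: hydrogen in place of bromo on an aromatic carbon. That step gave a 3.5-fold lower number from compound 1 to compound 2 (0.55 log units; beyond the scatter). The two cores differ only in one place, (chloro in place of fluoro on an aromatic carbon), and that difference gave a 1.8-fold higher number from compound 1 to compound 3 (0.25 log units; within the scatter), a gap that sits within the usual scatter, so the two cores behave alike as far as these numbers show.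

Because the earlier step of a 3.5-fold lower number from compound 1 to compound 2 (0.55 log units; beyond the scatter) points one way and the cores are so close, the same change is expected to give a similar step from compound 3, namely a 3.3-fold lower number from compound 3 to compound 4 (0.51 log units; beyond the scatter). Going by the values given here, with only one earlier example to rest on, the range is kept wide. Compound 4 is therefore estimated at 4500 nM, between 1800 nM and 12000 nM.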

Compound 4, half-maximal inhibitory concentration: 190 nM
Beside the measured number, compound 4's estimate is 24-fold (1.37 log units) above it; the whole stated range lies above it.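

In this assay, hydrogen in place of bromo gives a 77-fold lower number from compound 3 to compound 4 (1.89 log units; beyond the scatter), so the direction of the earlier step carried over to the new core but its size did not: the same change on two cores in this assay, a 3.5-fold lower number (0.55 log units; beyond the scatter) from compound 1 to compound 2 and a 77-fold lower number (1.89 log units; beyond the scatter) from compound 3 to compound 4, 22-fold (1.34 log units) apart, beyond the scatter of two such steps

Chloro in place of fluoro, read on the two compounds without bromo, gives a 12-fold lower number from compound 2 to compound 4 (1.09 log units; beyond the scatter), so this change also depends on the core that carries it: the same change on two cores in this assay, a 1.8-fold higher number (0.25 log units; within the scatter) from compound 1 to compound 3 and a 12-fold lower number (1.09 log units; beyond the scatter) from compound 2 to compound 4, 22-fold (1.34 log units) apart, beyond the scatter of two such steps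

Both comparisons rest on the same four compounds, so they describe a single interplay between the two changed places rather than two separate findings, and they do not show why it arises or whether it holds on any other core.

On these data alone, it remains open whether an amine or a methoxy group on that phenyl ring would behave like hydrogen or like bromo. As far as these compounds go, it is equally open how a carboxylic acid or a longer chain in place of the chloro would fit.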